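This account rests on a few compounds, and the source may have more. Where it says the series, first, only, none or still open, it means among the compounds named here.

Compound 1 `O=C(N/N=C/C1=C(Cl)c2ccccc2CCC1)c1ccccc1` is the reference point of the series. In a functional assay (MiaPaCa cells, Homo sapiens) for inhibition, read by sulforhodamine B assay, with a stated time of 48 h (on this read-out higher numbers stand for weaker inhibition of growth and lower numbers for stronger inhibition of growth), compound 1 gives 1000 nM. Compound 2 `Cc1ccc(C(=O)N/N=C/C2=C(Cl)c3ccccc3CCC2)cc1` differs from it by methyl in place of hydrogen on an aromatic carbon, cut one bond further out reading phenyl to 4-methylphenyl (methyl in place of hydrogen on an aromatic carbon). In this assay compound 2 gives 10000 nM, so the step is a 10-fold higher number from compound 1 to compound 2 (1.00 log units; beyond the scatter). Compound 3 `Cc1cc2c(cc1C)C(Cl)=C(/C=N/NC(=O)c1ccccc1)CCC2` has a different core; the difference between the two cores of compound 1 and compound 3 is not broken down here. For compound 3 this assay reports only a limit, > 100000 nM; this is the limit (the limit of > 100000 nM in this assay, at which 1 of the 3 values shown sits). Compound 4 `Cc1ccc(C(=O)N/N=C/C2=C(Cl)c3cc(C)c(C)cc3CCC2)cc1` is not yet measured. It stands to compound 3 as compound 2 stands to compound 1, with the same change at the same place (methyl in place of hydrogen on an aromatic carbon). Among the measured compounds shown here, the one measured instance of this change gave a 10-fold higher number from compound 1 to compound 2 (1.00 log units; beyond the scatter). On that basis the step is expected to be a step that the limit leaves unreadable from compound 3 to compound 4, toward weaker inhibition of growth, starting from a value that is already a limit. Compound 4 is therefore expected to give 300000 nM, most probably again reported only as a limit.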

Compound 4, concentration for 50% growth inhibition: 28800 nM
Beside the measured number, compound 4's estimate is 10-fold (1.02 log units) above it, and the stated range ends above it.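

In this assay methyl in place of hydrogen on an aromatic carbon gives an at least 3.4-fold lower number from compound 3 to compound 4 (0.54 log units; beyond the scatter), so the direction of the change does not carry over from the core of compound 1 to the core of compound 3: the same change on two cores in this assay, a 10-fold higher number (1.00 log units; beyond the scatter) from compound 1 to compound 2 and an at least 3.4-fold lower number (0.54 log units; beyond the scatter) from compound 3 to compound 4, at least 34-fold (1.54 log units) apart, beyond the scatter of two such steps

For compound 3 the assay gives only a limit, > 100000 nM.

Each core offers a single pair, so the result shows that a step measured on one core cannot be read across to the other in this series, but it does not show why the two cores part, how large the step on the second core really is, or whether the split holds beyond these compounds.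

From the compounds shown here alone, it remains open whether the reversal belongs to methyl alone or would also appear with a chlorine, a methoxy group or an amine at the same place on both cores. Also open, going by these compounds, is whether a carboxylic acid there would separate the two cores in the same way.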